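The source may report more compounds than this note shows. Statements on the series, on what has been measured and on what is new or still open speak of the compounds shown alone.

Notes on the series. Compound 1 `COc1ccc2c(=O)c(/C=C/C(=O)Nc3cccc(C)c3)coc2c1` carries 3-methylphenyl on the amide-type nitrogen. In a functional assay on HeLa cells (Homo sapiens) for inhibition, read by MTT assay, with a stated time of 48 h (on this read-out higher numbers stand for weaker inhibition and lower numbers for stronger inhibition), compound 1 gives > 100000 nM, a limit of the assay rather than a number, so compound 1 stands only at that limit. Compound 2 `COc1ccc2c(=O)c(/C=C/C(=O)NCc3ccccc3)coc2c1` gives 33400 nM in this assay. Compound 3 `COc1ccc2c(=O)c(/C=C/C(=O)NCc3ccc(C)cc3)coc2c1` gives > 100000 nM in this assay, again a limit and not a number. The step of an at least 2.9-fold lower number from compound 1 to compound 2 (0.47 log units; beyond the scatter) shows the gain from benzyl in place of 3-methylphenyl; the step of an at least 2.9-fold higher number from compound 2 to compound 3 (0.47 log units; beyond the scatter) shows that methyl in place of hydrogen on an aromatic carbon returns the value to the limit (the limit of > 100000 nM in this assay, at which 2 of the 3 values shown sit). Compound 4 `COc1ccc2c(=O)c(/C=C/C(=O)NCc3ccc(F)cc3F)coc2c1` is not yet measured; against compound 1 the change is 2,4-difluorobenzyl in place of 3-methylphenyl on an amide-type nitrogen. Both measured steps bear on it: the move to benzyl favours a lower number, while substitution on the benzyl ring in compound 3 removed that gain. A step of roughly an at least 1.6-fold lower number from compound 1 to compound 4 (0.22 log units; that floor lies within the scatter) is therefore expected, with a fair chance of another limit. Compound 4 is estimated at 60000 nM in this assay, within 20000 nM to 200000 nM.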

Compound 4, half-maximal inhibitory concentration: > 100000 nM
Compound 4 ended at the assay's limit (the forecaster's own chance of this, stated with the estimate: 45%); middle value at least 1.6-fold (0.22 log units) from the limit.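

In this assay 2,4-difluorophenyl in place of phenyl on the saturated chain carbon bound to the amide-type nitrogen loses the gain held by compound 2 (an at least 2.9-fold higher number from compound 2 to compound 4 (0.47 log units; beyond the scatter)), so this loss is no longer confined to the methyl group of compound 3. The steps to compound 4 from compound 1 and from compound 3 cannot be read, since both ends of each are limits. Of the compounds shown, only compound 2, with its unsubstituted benzyl group, gives a number rather than a limit: the limit of > 100000 nM in this assay, at which 3 of the 4 values shown sit.

Compounds 1, 3 and 4 cannot be ranked against one another while all three stand at the limit. On these data alone, whether a single fluorine, a methoxy group or an amine on the benzyl ring, or a longer chain on the amide-type nitrogen, would keep or improve the value of compound 2 remains open.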